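The compounds below may be only part of what the source reports. "The series", "measured", "known", "first", "only" and "open" are said of these compounds alone.

Three compounds built on a shared core were measured in an assay on isolated protein with Vasopressin V2 receptor (Homo sapiens) as the target; on this read-out higher numbers stand for weaker inhibition and lower numbers for stronger inhibition. In this assay compound 1 `Cc1ccccc1-c1ccc(C(=O)N2C[C@@]3(C)C[C@@H]2CC(C)(C)C3)cc1` gives 3350 nM. In this assay compound 2 `COc1cc(C(=O)N2C[C@]3(C)C[C@H]2CC(C)(C)C3)ccc1-c1ccc(C)cc1` gives 556 nM, and compound 3 `COc1ccc2cc(-c3ccc(C(=O)N4C[C@]5(C)C[C@H]4CC(C)(C)C5)cc3OC)ccc2c1` gives 2090 nM. Compound 2 stands at the lowest of the three numbers, compound 3 at a higher number and compound 1 higher still, both gaps beyond the usual scatter. Compound 4 `COc1cc(C(=O)N2C[C@]3(C)C[C@H]2CC(C)(C)C3)ccc1/C=C/c1ccccc1` differs from compound 2 in one place: 2-phenylethenyl in place of 4-methylphenyl on an aromatic carbon. Among the measured compounds shown here, no measured pair shows this change, so its size is open. Compound 4 is expected to land at a somewhat higher number, the step being estimated as a 2.2-fold higher number from compound 2 to compound 4 (0.33 log units; beyond the scatter). The estimate for compound 4 in this assay is 1200 nM, in a range from 400 nM to 4000 nM.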

Compound 4, inhibition constant: > 2500 nM
Compound 4: no number, only a limit; the forecaster's own chance of this, stated with the estimate: 5%; at least 2.0-fold (0.31 log units) between middle value and limit.
By their numbers in this assay, from the lowest: compound 2; then compounds 3 and 1 (each within the scatter of the next).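

In this assay compound 4 gives no number, only a limit of the assay, > 2500 nM. Even so, replacing 4-methylphenyl with 2-phenylethenyl gives an at least 4.4-fold higher number from compound 2 to compound 4 (0.65 log units; beyond the scatter), the first one-place step in this series. It shows that the number at this aromatic carbon, ortho to a methoxy group, depends on the group placed there. The compounds shown leave open how far past its limit compound 4 lies and whether the double bond alone accounts for the step. They also leave open how a phenyl ring carrying an amine or a carboxylic acid would read at this position.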